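Solubility of a tert-butylphenyl analogue from a benzyl pair

A few compounds are considered here, and "the series" means these few. Any claim that something is new, unique, unknown or untested is made for them only; others in the source may bear on it.

Compound 3 `COc1cccc(CNCCCNc2ccnc3cc(Cc4cc(C)cc(C)c4)ccc23)c1O` gives 4200 nM in a physicochemical assay for solubility, with a stated time of 18 h, at pH 7.4 (on this read-out higher numbers stand for higher solubility and lower numbers for lower solubility), level with compound 1 `COc1cccc(CNCCCNc2ccnc3cc(Cc4ccc(F)cc4)ccc23)c1O`, which gives 4200 nM; together these are the lowest of the three numbers, while compound 2 `COc1ccc(F)cc1CNCCCNc1ccnc2cc(-c3ccc(C(C)(C)C)cc3)ccc12` gives 32000 nM, the furthest from compound 3. Going by the values given here, the only measured single change, no change at the digits printed from compound 1 to compound 3 (within the scatter), shows that swapping one benzyl for another at the same place on the core left the read-out unchanged within scatter. Compound 4 `COc1cccc(CNCCCNc2ccnc3cc(-c4ccc(C(C)(C)C)cc4)ccc23)c1O` differs from compound 3 by 4-(tert-butyl)phenyl in place of 3,5-dimethylbenzyl on an aromatic carbon. Among the compounds with values here, no measured step covers exactly this change; the one measured step concerns a different swap at that place and was flat. Within the data shown here, compound 2, which carries the same entering group but a different substituent on the amine, does show the highest number, though no single step links it to compound 4. A modest rise is therefore expected, a 1.9-fold higher number from compound 3 to compound 4 (0.28 log units; within the scatter), with wide uncertainty. Compound 4 is estimated at 8000 nM, between 2500 nM and 25000 nM.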

Compound 4, solubility: 32000 nM
Compound 4: the middle estimate sits 4.0-fold (0.60 log units) below what was measured; measured number above the stated range.
By their numbers in this assay, from the lowest: compounds 1 and 3 (each within the scatter of the next); then compounds 2 and 4 (each within the scatter of the next).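

In this assay, replacing a benzyl group with 4-(tert-butyl)phenyl on this aromatic carbon gives a 7.6-fold higher number from compound 3 to compound 4 (0.88 log units; beyond the scatter) and likewise a 7.6-fold higher number from compound 1 to compound 4 (0.88 log units; beyond the scatter) for the 4-fluorobenzyl starting point, so this position can move the read-out although the benzyl-for-benzyl swap left it flat. With 4-(tert-butyl)phenyl held in place, 2-hydroxy-3-methoxyphenyl in place of 5-fluoro-2-methoxyphenyl gives no change at the digits printed from compound 2 to compound 4 (within the scatter) and so shows no effect of that change on the read-out. There is no evidence here that accounts for the rise.

The step changes the linking carbon and the ring substituent together, so the compounds shown do not separate the two. On these data alone, a 4-(tert-butyl)benzyl group or an unsubstituted phenyl at this place would be needed to tell them apart, and what an amine on that ring would do remains open.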